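Ring-substituted vinyl sulfoxide chromones: cytotoxicity on A549 cells

This account rests on a few compounds, and the source may have more. Where it says the series, first, only, none or still open, it means among the compounds named here.

Measured so far:
- compound 1 `C[S+]([O-])/C=C/c1cc(=O)c2ccccc2o1`: 1900 nM
- compound 2 `Cc1c(/C=C/[S+](C)[O-])oc2ccccc2c1=O`: 1500 nM
- compound 3 `COc1cccc2c(=O)cc(/C=C/[S+](C)[O-])oc12`: 2200 nM

All three were tested in a functional assay on A549 cells (Homo sapiens) for cytotoxicity, with a stated time of 48 h; a lower number here means a stronger inhibitor, a higher number a weaker inhibitor. Compound 1 holds the second highest of the three numbers; compound 3 lies nearest to it and compound 2 furthest, yet both gaps fall within the scatter, so the three compounds cannot be ordered on these data.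

Compound 4 `CCCOc1ccc2oc(/C=C/[S+](C)[O-])cc(=O)c2c1` has not yet been measured in this assay. It differs from compound 1 in one place: propoxy in place of hydrogen on an aromatic carbon. The two measured single-point changes on the same aromatic ring of the shared core are the relevant precedents: a 1.3-fold lower number from compound 1 to compound 2 (0.10 log units; within the scatter) and a 1.2-fold higher number from compound 1 to compound 3 (0.06 log units; within the scatter). Neither change moved the number beyond the scatter. Going by the values given here, a propoxy group has no measured precedent, so the expectation rests on these two steps alone and no step beyond the scatter is anticipated in either direction.

Compound 4 is therefore expected to give 1900 nM in this assay, with a range of 900 nM to 4000 nM, which means an expected step of no change at the digits printed from compound 1 to compound 4 (within the scatter).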

Compound 4, half-maximal inhibitory concentration: 1100 nM
Estimate against measurement, compound 4: 1.7-fold (0.24 log units) above, and the stated range covers the measured number.
By their numbers in this assay, from the lowest: compounds 4, 2, 1 and 3 (each within the scatter of the next).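

In this assay, the step of a 1.7-fold lower number from compound 1 to compound 4 (0.24 log units; within the scatter) shows that this aromatic carbon, meta to a fused ring and para to a fused ring, accepts a propoxy group without leaving the scatter. Going by these compounds alone, compounds 2 and 3 carry their methyl and methoxy groups on other carbons of the shared core, so compound 4 gives the first reading at this carbon and the first for a chain of this length on the series. The data give no measured basis for explaining this result.

From the compounds shown here alone, it remains open whether a butoxy chain or a longer one, an amine or a carboxylic acid on this same carbon would move the number beyond the scatter. Going by these compounds, it is also open whether propoxy on the other ring carbons would give a step of similar size.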